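From Chloro to Methyl on the Shared Core

This account rests on a few compounds, and the source may have more. Where it says the series, first, only, none or still open, it means among the compounds named here.

Measured so far in an ADME assay on RD cells (Homo sapiens) for cytotoxicity, read by MTT assay, with a stated time of 3 days; a higher number here means that more compound is tolerated, a lower number that less compound is tolerated
Compound 1 `CC[C@H](CCn1cncn1)c1ccc(C)cc1` gives 85.2 ug/mL here
Compound 2 `CCC[C@@H](CCn1cncn1)c1ccc(Cl)cc1` gives 40.8 ug/mL here

Compound 2 holds the lower of the two numbers, and its gap to compound 1 lies beyond the usual scatter. Compound 3 `CCC[C@@H](CCn1cncn1)c1ccc(C)cc1` departs from compound 2 at one place methyl in place of chloro on an aromatic carbon with methyl in place of chloro on an aromatic carbon. Compound 1 also carries that methyl and gives 85.2 ug/mL in a structure that differs elsewhere too. In this assay a small rise within the scatter is therefore expected, and the estimated change is a 1.4-fold higher number from compound 2 to compound 3 (0.15 log units; within the scatter) as a rough figure. For compound 3 the expected value is 58 ug/mL with an estimated range from 30 ug/mL to 110 ug/mL in this assessment.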

Compound 3, half-maximal cytotoxic concentration: 74.1 ug/mL
Compound 3: the middle estimate sits 1.3-fold (0.11 log units) below what was measured; low and high end bracket the measured number.
By their numbers in this assay, from the lowest: compounds 2, 3 and 1 (each within the scatter of the next, the first and the last beyond it).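

In this assay, methyl in place of chloro on an aromatic carbon, para to a large group, gives a step that stays within the scatter (a 1.8-fold higher number from compound 2 to compound 3 (0.26 log units; within the scatter)). The earlier compounds shown here differed in more than one place, whereas this pair isolates the exchange at this position, and on this evidence the two groups are not told apart. No accompanying measurement points to a cause for this step. Going by these compounds, what an amine, a methoxy group or a carboxylic acid at this place would give remains open.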